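The compounds below may be only part of what the source reports. "The series", "measured", "known", "first", "only" and "open" are said of these compounds alone.

Of the compounds shown here, three built on one shared core have been tested in a functional assay on NCI-H1299 cells (Homo sapiens) for antiproliferative activity, read by MTT assay, with a stated time of 72 h; on this read-out lower numbers stand for stronger inhibition and higher numbers for weaker inhibition. Compound 1 `CC(C)OC1=C(C(=O)c2ccccc2)C(c2ccc(Br)cc2)N(CCCn2ccnc2)C1=O` gives 18900 nM. Compound 2 `CCCCOC1=C(C(=O)c2ccccc2)C(c2ccc(Br)cc2)N(CCCn2ccnc2)C1=O` gives 17100 nM. Compound 3 `NC1=C(C(=O)c2ccccc2)C(c2ccc(Br)cc2)N(CCCn2ccnc2)C1=O` gives 169000 nM, the highest number of the three and therefore the weakest inhibition. The step of an 8.9-fold higher number from compound 1 to compound 3 (0.95 log units; beyond the scatter) and the step of a 9.9-fold higher number from compound 2 to compound 3 (0.99 log units; beyond the scatter) point the same way, whereas a 1.1-fold lower number from compound 1 to compound 2 (0.04 log units; within the scatter) shows nothing that counts.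

Compound 4 `O=C(C1=C(Nc2ccc(Cl)cc2)C(=O)N(CCCn2ccnc2)C1c1ccc(Br)cc1)c1ccccc1` has not yet been measured. It differs from compound 3 by 4-chlorophenyl in place of hydrogen on an amine nitrogen. Among the measured compounds shown here, no measured step covers this kind of change: the two informative steps compare an isopropoxy or butoxy group with an amino group, not an amino group with a (4-chlorophenyl)amino group. All that is known is that compound 3 stands at the weak end of the set, so the number for compound 4 could move in either direction, and the estimate must be wide. Compound 4 is expected to give 40000 nM in this assay, with a range from 8000 nM to 200000 nM. This amounts to an expected step of a 4.2-fold lower number from compound 3 to compound 4 (0.63 log units; beyond the scatter), offered as a loosely supported guess rather than a firm prediction.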

Compound 4, half-maximal inhibitory concentration: 25000 nM
Compound 4: middle estimate off by 1.6-fold (0.20 log units), on the high side, within the range that was stated.
By their numbers in this assay, from the lowest: compounds 2, 1 and 4 (each within the scatter of the next); then compound 3.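

In this assay, the amine nitrogen on the double-bonded ring carbon accepts a substituent, and 4-chlorophenyl in place of hydrogen gives a 6.8-fold lower number from compound 3 to compound 4 (0.83 log units; beyond the scatter), so the weak result for compound 3 does not extend to every group joined through nitrogen at this place. The steps of a 1.5-fold higher number from compound 2 to compound 4 (0.16 log units; within the scatter) and a 1.3-fold higher number from compound 1 to compound 4 (0.12 log units; within the scatter) both lie within the scatter, so (4-chlorophenyl)amino cannot be told apart here from butoxy or isopropoxy, and the earlier gap between oxygen-linked groups and amino does not hold for nitrogen-linked groups as a whole. No available evidence accounts for this change in the numbers.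

On these data alone, it remains open whether the gain comes from the aromatic ring or from its chlorine, a question that plain phenyl on this nitrogen would address. As far as these compounds go, it is also open how a small methyl or a longer butyl chain on the same nitrogen would compare.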